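The source may report more compounds than this note shows. Statements on the series, on what has been measured and on what is new or still open speak of the compounds shown alone.

Measured compounds:
Compound 1, `O=[N+]([O-])c1cn2c(n1)OC[C@@H](OCCOc1ccc(-c3ccc(OC(F)(F)F)cc3)cc1)C2`, in a physicochemical assay for solubility, read by HPLC, at pH 7 (on this read-out higher numbers stand for higher solubility and lower numbers for lower solubility), gives 0.68 ug/mL.
Compound 2, `O=[N+]([O-])c1cn2c(n1)OC[C@@H](OCCOc1ccc(OCc3ccccc3)cc1)C2`, in this assay gives 1.7 ug/mL.
Compound 3, `O=[N+]([O-])c1cn2c(n1)OC[C@@H](OCC#Cc1ccc(OCc3ccccc3)cc1)C2`, in this assay gives 0.43 ug/mL.

Compound 1 and compound 2 share one core and differ at a single place: 4-(trifluoromethoxy)phenyl in place of benzyloxy on an aromatic carbon. That change produced a 2.5-fold lower number from compound 2 to compound 1 (0.40 log units; beyond the scatter). Compound 3 carries a different core; the difference between the core of compound 3 and that of compound 2 is not broken down here. The value of compound 3 and that of compound 1 lie within the usual scatter of each other, whereas compound 2 stands beyond the scatter above compound 3.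

Compound 4, `O=[N+]([O-])c1cn2c(n1)OC[C@@H](OCC#Cc1ccc(-c3ccc(OC(F)(F)F)cc3)cc1)C2`, is not yet measured in this assay. It is related to compound 3 by 4-(trifluoromethoxy)phenyl in place of benzyloxy on an aromatic carbon. The place line reads the same for both pairs, so this is the same change as that between compound 2 and compound 1, made here on the core of compound 3 instead. Because the earlier instance gave a 2.5-fold lower number from compound 2 to compound 1 (0.40 log units; beyond the scatter), and the pair of cores differs only in a part that is not itself a counted change, the step from compound 3 to compound 4 is expected to be of similar size, with wider uncertainty since it rests on a single precedent: a 2.4-fold lower number from compound 3 to compound 4 (0.38 log units; beyond the scatter). On that basis compound 4 is estimated to give 0.18 ug/mL in this assay, within a range from 0.08 ug/mL to 0.45 ug/mL.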

Compound 4, solubility: 0.07 ug/mL
Estimate against measurement, compound 4: 2.6-fold (0.41 log units) above; the measured number lies below the stated range.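

In this assay the change to 4-(trifluoromethoxy)phenyl in place of benzyloxy on an aromatic carbon lowers the number again, giving a 6.1-fold lower number from compound 3 to compound 4 (0.79 log units; beyond the scatter) against a 2.5-fold lower number from compound 2 to compound 1 (0.40 log units; beyond the scatter) on the core of compound 2, so across these two pairs the direction carries from one core to the other and both steps lie beyond the scatter. Among the compounds shown here, the size does not carry over unchanged: the step on the core of compound 3 is the larger of the two, and with only one pair on each core this shows neither that the core sets the size nor how large the step would be on a third core. Nothing given here accounts for the difference between the two steps.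

The compounds shown leave open whether the same lowering would appear if the entering group carried an amine or a carboxylic acid instead of the trifluoromethoxy group. They also leave open how the step would behave on a core with a longer chain than those of compound 2 and compound 3, and so whether the direction seen in these two pairs holds beyond them.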